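The source may report more compounds than this note shows. Statements on the series, on what has been measured and on what is new or still open speak of the compounds shown alone.

Measured so far:

Compound 1 `CCN(CC)CC(=O)OC1CC2(N3CCCCC3)CC(c3ccccc3)C1C(c1ccccc1)C2` — 23900 nM
Compound 2 `CCN(CC)CC(=O)OC1CC2(N3CCCC3)CC(c3ccccc3)C1C(c1ccccc1)C2` — 49000 nM
Compound 3 `CN1CCN(CCC(=O)N2CCC3(N4CCCC4)CC(c4ccccc4)C2C(c2ccccc2)C3)CC1` — 75400 nM

In an ADME assay on L6 cells (Rattus norvegicus) for cytotoxicity, read by resazurin assay, with a stated time of 72 h (a higher number here means a weaker inhibitor, a lower number a stronger inhibitor), compound 1 gives the lowest of the three numbers. Within the data shown here, compound 2 lies nearest to it, and the one measured step, a 2.1-fold higher number from compound 1 to compound 2 (0.31 log units; beyond the scatter), is modest but beyond the scatter. Among the measured compounds shown here, compound 3 lies furthest from compound 1; no single step links these two, as compound 3 differs from compound 2 in more than one place, and its values show only that the amide-bearing compound 3 sits higher than compound 2 in this assay.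

Compound 4 `CN1CCN(CC(=O)NC2CC3(N4CCCCC4)CC(c4ccccc4)C2C(c2ccccc2)C3)CC1` keeps the core of compound 1 and changes one thing: (((4-methylpiperazin-1-yl)methyl)carbonyl)amino in place of (((diethylamino)methyl)carbonyl)oxy on a saturated ring carbon. For the measured compounds named here, no measured step covers this exact change. The step from compound 1 to compound 2 concerns another position and does not bear on it directly. Going by the values given here, the only hint is that compound 3, which carries a methylpiperazine-bearing amide, shows a higher number than compounds 1 and 2 in this assay, though its core differs. Compound 4 is therefore expected to give 40000 nM in this assay, with a likely range of 15000 nM to 100000 nM. This estimate means a step of a 1.7-fold higher number from compound 1 to compound 4 (0.22 log units; within the scatter), expected to be modest and possibly within the scatter.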

Compound 4, half-maximal inhibitory concentration: 57500 nM
For compound 4 the middle estimate is 1.4-fold (0.16 log units) below the measured one; low and high end bracket the measured number.
By their numbers in this assay, from the lowest: compound 1; then compounds 2, 4 and 3 (each within the scatter of the next).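

Among these compounds, compound 4 gives the first reading at the saturated ring carbon itself: in this assay, placing (((4-methylpiperazin-1-yl)methyl)carbonyl)amino there in place of (((diethylamino)methyl)carbonyl)oxy gives a 2.4-fold higher number from compound 1 to compound 4 (0.38 log units; beyond the scatter), so this position responds to a change while the piperidin-1-yl group stays in place. Among the compounds shown here, until now the only measured step, a 2.1-fold higher number from compound 1 to compound 2 (0.31 log units; beyond the scatter), concerned the ring carbon that bears the piperidin-1-yl group, so the two steps together show that the number moves beyond the scatter with a change at either place, each time upward from compound 1. Nothing measured here gives a reason for the step to compound 4.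

The swap alters both the oxy link, which becomes amino, and the diethylamino end, which becomes 4-methylpiperazin-1-yl, so the compounds shown cannot say which of the two carries the step; (((diethylamino)methyl)carbonyl)amino or (((4-methylpiperazin-1-yl)methyl)carbonyl)oxy at this carbon would separate them. Also open, from the compounds shown here alone, is how the number responds to a longer chain between the carbonyl and the terminal amine, or to a morpholine in place of the methylpiperazine.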